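Cycloheptyl for fluorophenyl on the ring nitrogen

A few compounds are considered here, and "the series" means these few. Any claim that something is new, unique, unknown or untested is made for them only; others in the source may bear on it.

Three compounds have been measured in an assay on Huh-7 cells for agonist activity at Bile acid receptor (Homo sapiens), read by a luciferase reporter; on this read-out lower numbers stand for an effect already at smaller amounts and higher numbers for an effect only at larger amounts of compound:
compound 1, `CC(C)c1onc(-c2c(Cl)cccc2Cl)c1COc1ccc(-c2nc3cc(C(=O)O)ccc3n2C)cc1`, gives 25.8 nM
compound 2, `CC(C)c1onc(-c2c(Cl)cccc2Cl)c1COc1ccc(-c2nc3ccc(C(=O)O)cc3n2-c2ccc(F)cc2)cc1`, gives 32.2 nM
compound 3, `CCC(CC)n1c(-c2ccc(OCc3c(-c4c(Cl)cccc4Cl)noc3C(C)C)cc2Cl)nc2ccc(C(=O)O)cc21`, gives 1.6 nM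

Compound 2 has the highest number of the three. Compound 1 stands within the usual scatter of compound 2, so the two cannot be told apart on this read-out. Within the data shown here, compound 3 sits far below both, beyond the scatter, though compound 3 differs from compound 2 in more than one place and no single step between them is given.

Compound 4, `CC(C)c1onc(-c2c(Cl)cccc2Cl)c1COc1ccc(-c2nc3ccc(C(=O)O)cc3n2C2CCCCCC2)cc1`, is not yet measured. It differs from compound 2 by cycloheptyl in place of 4-fluorophenyl on an aromatic nitrogen.

Among the measured compounds shown here, no step between measured compounds isolates this kind of change. Still, the branched alkyl group on the same ring nitrogen of compound 3 goes with the lowest number seen, and compound 4 carries a saturated ring there in place of the aromatic one. The step from compound 2 to compound 4 is therefore expected to be a lowering of the number in this assay, by a 3.2-fold lower number from compound 2 to compound 4 (0.51 log units; beyond the scatter), with the caveat that compound 3 also carries a chlorine not present in compound 4. Compound 4 is estimated to give 10 nM in this assay, within a range of 3 nM to 35 nM.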

Compound 4, half-maximal effective concentration: 14.8 nM
Compound 4: middle estimate off by 1.5-fold (0.17 log units), on the low side; the measured number falls inside the stated range.
By their numbers in this assay, from the lowest: compound 3; then compounds 4, 1 and 2 (each within the scatter of the next, the first and the last beyond it).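

In this assay, the change on the aromatic nitrogen gives a 2.2-fold lower number from compound 2 to compound 4 (0.34 log units; beyond the scatter), a modest step but one beyond the scatter. Among these compounds, it is the first comparison at this position in which only the group on that nitrogen differs, and it shows that a non-aromatic ring of carbon only can replace the aromatic ring of 4-fluorophenyl without a rise in the number. No measurement shown explains the step.

The compounds shown leave open whether the step follows from the loss of the aromatic ring or of the fluorine, which plain phenyl on the same nitrogen could separate. They also leave open how ring size and ring content act here, as cyclopentyl or a saturated ring carrying an amine would show.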